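Cyclohexyl for 4-Chlorophenyl on the Ether Chain

The source may hold more compounds than are shown below. What is called first, only, known or untested is meant among the compounds shown, and "the series" means these compounds.

In a functional assay on RAW264.7 cells (Mus musculus) for inhibition, read by Griess assay, with stated times of 1 h and 24 h (on this read-out lower numbers stand for stronger inhibition and higher numbers for weaker inhibition), compound 1 `CCOc1ccc(C(O)C2OC(=O)c3c(OC)cc(OC)cc32)cc1` reads > 10000 nM, which is a limit of the assay. Going by the values given here, compound 2 `COc1cc(OC)c2c(c1)C(C(O)c1ccc(OCc3ccc(Cl)cc3)cc1)OC2=O` gives 4320 nM, the only actual number so far. Compound 3 `COc1cc(OC)c2c(c1)C(C(O)c1ccc(OCC3CCCCC3)cc1)OC2=O` carries cyclohexyl in place of 4-chlorophenyl on a saturated chain carbon bound to an oxygen on an aromatic ring. Among the compounds with values here, the one measured step bearing on this is an at least 2.3-fold lower number from compound 1 to compound 2 (0.36 log units; beyond the scatter), but it replaced methyl, not one ring with another. No step beyond the scatter is therefore expected in this assay, and no direction is favoured. The expected step is a 1.0-fold higher number from compound 2 to compound 3 (0.02 log units; within the scatter). Compound 3 is estimated at 4500 nM, within a range of 1800 nM to 10000 nM.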

Compound 3, half-maximal inhibitory concentration: > 10000 nM
Compound 3: no number, only a limit; the forecaster's own chance of this, stated with the estimate: 20%; middle value at least 2.2-fold (0.34 log units) from the limit.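

In this assay, this position now shows that the ring on the ether chain cannot be exchanged freely: cyclohexyl in place of 4-chlorophenyl gives an at least 2.3-fold higher number from compound 2 to compound 3 (0.36 log units; beyond the scatter). The earlier step showed only that 4-chlorophenyl improved on methyl, whereas this one shows that a six-membered carbon ring alone does not preserve that gain. Going by these compounds alone, no step between compound 1 and compound 3 can be read, since both values are limits.

Whether the chlorine or the aromatic ring accounts for the difference remains open, and an unsubstituted benzyl group on the same oxygen would separate the two. Finer ranking at the weak end is also unavailable: the limit of > 10000 nM in this assay, at which 2 of the 3 values shown sit.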